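This account rests on a few compounds, and the source may have more. Where it says the series, first, only, none or still open, it means among the compounds named here.

Compound 1, with the structure `COc1cc(-c2ncnn2-c2ccccc2)cc(OC)c1OC`, and compound 2, with the structure `COc1cc(-n2ncnc2-c2ccccc2)cc(OC)c1OC`, are built from the same atoms joined differently; the difference between the two cores is not broken down here. In a functional assay on K562 cells (Homo sapiens) for antiproliferative activity, read by MTT assay, with a stated time of 72 h (on this read-out lower numbers stand for stronger inhibition and higher numbers for weaker inhibition), compound 1 gives > 10000 nM, which is a limit of the assay rather than a number. In this assay compound 2 likewise gives only a limit, > 10000 nM. Compound 3, with the structure `COc1cc(-n2ncnc2-c2cccc([N+](=O)[O-])c2)cc(OC)c1OC`, differs from compound 2 by nitro in place of hydrogen on an aromatic carbon. In this assay compound 3 again reaches only a limit, > 10000 nM. The step from compound 2 to compound 3 is therefore a step that the two limits leave unreadable from compound 2 to compound 3, and all that can be said of the three measured values is the limit of > 10000 nM in this assay, at which 3 of the 3 values shown sit.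

Compound 4, with the structure `COc1cc(-c2ncnn2-c2cccc([N+](=O)[O-])c2)cc(OC)c1OC`, is not yet measured. Among the measured compounds shown here, it differs from compound 1 by nitro in place of hydrogen on an aromatic carbon, the same change, at the same kind of place, as the one that separates compound 3 from compound 2. On these data alone, on the core of compound 2 that change left both ends at the limit, so its size is unknown. The step from compound 1 to compound 4 is expected to be a step that the limit leaves unreadable from compound 1 to compound 4, and this expectation rests on nothing firmer than the unreadable step that the two limits leave unreadable from compound 2 to compound 3 and the fact that (the limit of > 10000 nM in this assay, at which 3 of the 3 values shown sit). Compound 4 is accordingly estimated at 20000 nM in this assay, with a range from 5000 nM to 100000 nM, and it is expected that this assay will most probably report only a limit for it.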

Compound 4, half-maximal inhibitory concentration: > 10000 nM
Compound 4: no number, only a limit (the forecaster's own chance of this, stated with the estimate: 85%); the middle value is on the limit's open side.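

In this assay compound 4 and compound 1 both stop at a limit, so nitro in place of hydrogen gives no readable step between them, just as it gave none between compound 2 and compound 3: the limit of > 10000 nM in this assay, at which 4 of the 4 values shown sit.

The compounds shown leave open what any of the four would give as an actual number in this assay, and whether nitro in place of hydrogen has any effect on either core.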